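A Trifluoromethyl Swap at the Edge of Measurable Activity

This account rests on a few compounds, and the source may have more. Where it says the series, first, only, none or still open, it means among the compounds named here.

For the measured compounds named here, in a functional assay on HepG2 cells (Homo sapiens) for antiproliferative activity, read by spectrophotometry, with a stated time of 2 days (on this read-out lower numbers stand for stronger inhibition of growth and higher numbers for weaker inhibition of growth), compound 3 `Cc1cc(Cl)ccc1Nc1ncc(C(F)(F)F)c(N2Cc3cccc(N(C)S(C)(=O)=O)c3C2)n1` gives 19600 nM, the only actual number among the three measured compounds. Compound 1 `COc1ccc(Nc2ncc(C(F)(F)F)c(N3Cc4cccc(N(C)S(C)(=O)=O)c4C3)n2)cc1C(F)(F)F` gives only a limit, > 30000 nM. Compound 2 `Cc1ccc(Nc2ncc(C(F)(F)F)c(N3Cc4cccc(N(C)S(C)(=O)=O)c4C3)n2)cc1C` also gives only a limit, > 30000 nM. Compound 4 `CN(c1cccc2c1CN(c1nc(Nc3ccc(Cl)c(C(F)(F)F)c3)ncc1C(F)(F)F)C2)S(C)(=O)=O` differs from compound 3 by one change 4-chloro-3-(trifluoromethyl)phenyl in place of 4-chloro-2-methylphenyl on a nitrogen on an aromatic ring. Two measured steps exchange groups at this place, an at least 1.5-fold lower number from compound 1 to compound 3 (0.18 log units; that floor lies within the scatter) and an at least 1.5-fold lower number from compound 2 to compound 3 (0.18 log units; that floor lies within the scatter), and the floor of each lies within the scatter. The expected step in this assay is therefore a 1.3-fold higher number from compound 3 to compound 4 (0.11 log units; within the scatter), none beyond the scatter. Compound 4 is estimated at 25000 nM, with an expected range from 9000 nM to 60000 nM.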

Compound 4, concentration for 50% growth inhibition: 16000 nM
Beside the measured number, compound 4's estimate is 1.6-fold (0.19 log units) above it; measured number inside the range.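

In this assay, a second group at this place now gives a real number, and swapping 4-chloro-2-methylphenyl for 4-chloro-3-(trifluoromethyl)phenyl gives a 1.2-fold lower number from compound 3 to compound 4 (0.09 log units; within the scatter), so the two chlorinated groups are not told apart. Chloro in place of methoxy gives an at least 1.8-fold lower number from compound 1 to compound 4 (0.27 log units; that floor lies within the scatter), and the change from 3,4-dimethylphenyl gives an at least 1.8-fold lower number from compound 2 to compound 4 (0.27 log units; that floor lies within the scatter). Both steps start from a limit and give only floors: the limit of > 30000 nM in this assay, at which 2 of the 4 values shown sit.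

On these data alone, it remains open whether an amine or a carboxylic acid on this phenyl group would move the number beyond the scatter.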